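The source may report more compounds than this note shows. Statements on the series, on what has been measured and on what is new or still open speak of the compounds shown alone.

Compound 1 `COc1ccc(CNCCCNS(=O)(=O)c2cc(C(F)(F)F)cc(C(F)(F)F)c2)cc1OC` gives 3500 nM in a functional assay on HPAC cells (Homo sapiens) for inhibition, read by MTT assay, with a stated time of 72 h; a lower number here means a stronger inhibitor of growth, a higher number a weaker inhibitor of growth. Compound 2 `O=S(=O)(NCCCNCC1COc2ccccc2O1)c1cc(C(F)(F)F)cc(C(F)(F)F)c1` gives 2700 nM in this assay, and compound 3 `CN(CCCNS(=O)(=O)c1cc(C(F)(F)F)cc(C(F)(F)F)c1)Cc1ccccc1` gives 30000 nM in this assay. Among the measured compounds shown here, compound 2 stands with compound 1 inside the scatter, while compound 3 shows a higher number, beyond the scatter; the only single-place change measured so far is a 1.3-fold lower number from compound 1 to compound 2 (0.11 log units; within the scatter). Compound 4 `O=S(=O)(NCCCNCc1ccc(Cl)cc1)c1cc(C(F)(F)F)cc(C(F)(F)F)c1` is not yet measured; it differs from compound 2 by 4-chlorophenyl in place of 2,3-dihydro-1,4-benzodioxin-2-yl on a saturated chain carbon bound to an amine nitrogen. For the measured compounds named here, the one step that bears on this change is a 1.3-fold lower number from compound 1 to compound 2 (0.11 log units; within the scatter), in which the group on the same saturated chain carbon was exchanged without a shift beyond the scatter. Compound 3 differs from compound 1 in more than one place, so its gap to compound 1 gives no guide for an exchange at this position alone. Going by the values given here, with only this small precedent, no step beyond the scatter is expected for a 1.1-fold higher number from compound 2 to compound 4 (0.05 log units; within the scatter). Compound 4 is therefore expected to give about 3000 nM in this assay, within 1200 nM to 7500 nM.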

Compound 4, concentration for 50% growth inhibition: 2800 nM
Compound 4: middle estimate off by 1.1-fold (0.03 log units), on the high side; low and high end bracket the measured number.
By their numbers in this assay, from the lowest: compounds 2, 4 and 1 (each within the scatter of the next); then compound 3.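

In this assay, this position on the saturated chain carbon bound to an amine nitrogen tolerates a further exchange: 4-chlorophenyl for 2,3-dihydro-1,4-benzodioxin-2-yl gives no shift beyond the scatter (a 1.0-fold higher number from compound 2 to compound 4 (0.02 log units; within the scatter)), and the same holds for 4-chlorophenyl for 3,4-dimethoxyphenyl (a 1.3-fold lower number from compound 1 to compound 4 (0.10 log units; within the scatter)). Compounds 1, 2 and 4 thus stay together despite different ring groups, while the large step (an 11-fold lower number from compound 3 to compound 4 (1.03 log units; beyond the scatter)) joins two differences, the methyl on the amine and the chlorine on the benzyl group, and cannot be assigned to either one alone. No measurement shown here accounts for these numbers.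

Still open, going by these compounds, is whether a plain benzyl on the secondary amine stays with compounds 1, 2 and 4, or a methyl on the amine of compound 4 moves the number toward that of compound 3. On these data alone, a longer chain between the sulfonamide nitrogen and the amine also remains untested in these compounds.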